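This account rests on a few compounds, and the source may have more. Where it says the series, first, only, none or still open, it means among the compounds named here.

In a functional assay on TK-10 cells (Homo sapiens) for cytotoxicity, read by sulforhodamine B assay, with a stated time of 48 h, tested at 0.01 uM (a higher number here means a weaker effect of the compound at the concentration tested, a lower number a stronger effect), three compounds have been measured so far. Compound 1 `COc1cc(C)cc(-c2c(-c3ccnc(-c4ccc(C(C)=O)cc4)c3)cnn2CC#N)c1` gives 100% in this assay, and compound 2 `COc1cc(C)cc(-c2nn(CC#N)cc2-c2ccc(-c3cccc(C(C)=O)c3)nc2)c1` gives 100%, so the two are level at the digits reported and together are the lowest of the three numbers. Among the measured compounds shown here, compound 3 `COc1cc(C)cc(-c2nn(CC#N)cc2-c2ccnc(-c3ccc(N(C)C)cc3)c2)c1` gives 119% in this assay, a number that sits beyond the usual scatter from compound 1, which makes compound 3 the one furthest from compound 1 among the measured compounds.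

Compound 4 `COc1cc(C)cc(-c2c(-c3ccnc(-c4ccc(N(C)C)cc4)c3)cnn2CC#N)c1` has not been measured yet. It differs from compound 1 in one place: dimethylamino in place of acetyl on an aromatic carbon. For the measured compounds named here, no pair of measured compounds shows exactly this change, so its effect can only be guessed from what is already known. Compound 3 also carries a dimethylamino group and gives 119%, which is the highest number seen here. On that basis a small step upward, or none beyond the scatter, is expected from compound 1 to compound 4 in this assay, namely a number 8 percentage points higher from compound 1 to compound 4 (within the scatter). The value expected for compound 4 is therefore 108%, with a range from 92% to 125%.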

Compound 4, a percentage reported as activity, at one concentration (the size of the read-out at that concentration, not a potency): 75%
Beside the measured number, compound 4's estimate is 33 percentage points above it; the whole stated range lies above it.
By their numbers in this assay, from the lowest: compound 4; then compounds 1 and 2 (each within the scatter of the next); then compound 3.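

In this assay, putting dimethylamino in place of acetyl on this aromatic carbon gives a number 25 percentage points lower from compound 1 to compound 4 (beyond the scatter), so the group at this spot alone can shift the read-out towards a stronger effect at the concentration tested, while the rest of the molecule stays the same. The change is also subtle on paper: both groups have the same number of heavy atoms and hydrogen-bond acceptors, no hydrogen-bond donors and no net charge, but acetyl brings an oxygen and a double bond outside the aromatic rings, whereas dimethylamino brings a nitrogen. Nothing measured here explains why the two groups differ in this assay.

Going by these compounds, this single pair gives no trend, and a read-out at one concentration is not a potency, so how large the difference would be across a range of concentrations remains unknown. On these data alone, it also remains open whether a smaller primary amine, a longer chain on the nitrogen or a carboxylic acid on the same carbon would move the number further, or back again.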